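From Fluoro to Nitro: Compound 4 Before Its Measurement

The compounds below may be only part of what the source reports. "The series", "measured", "known", "first", "only" and "open" are said of these compounds alone.

Measured so far in a functional assay on BMDM cells (Mus musculus, strain C57BL/6) for inhibition, with a stated time of 2 days; on this read-out lower numbers stand for stronger inhibition and higher numbers for weaker inhibition:
compound 1, `COc1ccc(-c2cn(CC(=O)Nc3nc4ccccc4s3)nn2)cc1`: compound 1 gives 1330 nM
compound 2, `O=C(Cn1cc(-c2ccc(F)cc2)nn1)Nc1nc2ccccc2s1`: compound 2 reaches only a limit, > 30000 nM
compound 3, `Cc1cc(NC(=O)Cn2cc(-c3ccc(F)cc3)nn2)no1`: compound 3 likewise reaches only a limit, > 30000 nM

Compound 2 therefore stands at the limit of this assay, as noted: the limit of > 30000 nM in this assay, at which 2 of the 3 values shown sit. Compound 4, `O=C(Cn1cc(-c2ccc([N+](=O)[O-])cc2)nn1)Nc1nc2ccccc2s1`, differs from compound 2 by nitro in place of fluoro on an aromatic carbon. Among the measured compounds shown here, the only measured step at this position is an at least 22-fold higher number from compound 1 to compound 2 (1.35 log units; beyond the scatter), a large loss, and no compound bearing a nitro group has been measured. With compound 2 at a limit, any change would have to be a large gain to show as a number. Compound 4 is thus expected near the limit, perhaps slightly inside it, at 15000 nM, ranging from 3000 nM to 40000 nM. That corresponds to an expected step of an at least 2.0-fold lower number from compound 2 to compound 4 (0.30 log units; that floor lies within the scatter).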

Compound 4, half-maximal inhibitory concentration: 3280 nM
Beside the measured number, compound 4's estimate is 4.6-fold (0.66 log units) above it; the measured number falls inside the stated range.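

Fluoro is not the only outcome for a replacement of methoxy at this position: the change to nitro gives an at least 9.1-fold lower number from compound 2 to compound 4 (0.96 log units; beyond the scatter), bringing the series back into the measurable range. Nitro still falls short of methoxy, with a 2.5-fold higher number from compound 1 to compound 4 (0.39 log units; beyond the scatter). The first of these steps can be read only as a minimum, because compound 2 sits at a limit: the limit of > 30000 nM in this assay, at which 2 of the 4 values shown sit.

Open, on these data alone, is how an amine or a carboxylic acid at this position would compare with methoxy and nitro. Also open, as far as these compounds go, is whether the 4-fluorophenyl to 4-nitrophenyl change would act the same way on the core of compound 3.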